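A Bromophenyl Amide in a Cell Toxicity Test

The source may report more compounds than this note shows. Statements on the series, on what has been measured and on what is new or still open speak of the compounds shown alone.

Of the compounds shown here, two with a shared core have been measured so far in an ADME assay on MT4 cells (Homo sapiens) for cytotoxicity, read by MTT assay (on this read-out higher numbers stand for lower toxicity in this test and lower numbers for higher toxicity in this test), for this series. Compound 1 `O=C(CSc1nncnc1-c1ccccc1Cl)c1ccc(Cl)c(Cl)c1` gives 33000 nM there. Compound 2 `Cc1cnc(NC(=O)CSc2nncnc2-c2ccccc2Cl)c(Br)c1` gives 144000 nM and so holds the higher of the two numbers, meaning the lower toxicity in this test, with a gap to compound 1 that lies beyond the usual scatter.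

Compound 3 `O=C(CSc1nncnc1-c1ccccc1Cl)Nc1ccccc1Br` departs from compound 2 in one place. The change is 2-bromophenyl in place of 3-bromo-5-methylpyridin-2-yl on an amide-type nitrogen and in words it puts 2-bromophenyl in place of 3-bromo-5-methylpyridin-2-yl on an amide-type nitrogen. Among the measured compounds shown here, no two measured compounds differ in just one place, so no measured step guides this swap directly. With compound 1 at 33000 nM as the only lower reference, a modest move toward a lower number is expected, though this is thin evidence. The estimated change is a 2.4-fold lower number from compound 2 to compound 3 (0.38 log units; beyond the scatter) in this assay and it would only just clear the scatter. Compound 3 is expected at 60000 nM with 20000 nM to 150000 nM as its likely range.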

Compound 3, half-maximal cytotoxic concentration: 73000 nM
Compound 3: middle estimate off by 1.2-fold (0.09 log units), on the low side; low and high end bracket the measured number.
By their numbers in this assay, from the lowest: compound 1; then compounds 3 and 2 (each within the scatter of the next).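

In this assay, the swap on the amide-type nitrogen gives a 2.0-fold lower number from compound 2 to compound 3 (0.30 log units; within the scatter), which lies within the usual scatter. On this nitrogen, 2-bromophenyl and 3-bromo-5-methylpyridin-2-yl therefore cannot be told apart in this test, even though only the second carries a ring nitrogen and a hydrogen-bond acceptor. The other new step, placing (2-bromophenyl)amino on the carbonyl carbon in place of 3,4-dichlorophenyl, gives a 2.2-fold higher number from compound 1 to compound 3 (0.34 log units; beyond the scatter), a modest move beyond the scatter toward lower toxicity in this test, and there is no evidence at hand that would explain either step.

Both amides shown carry a bromine on their ring, so its part remains open, and a plain phenyl or a 2-chlorophenyl on the same nitrogen would speak to that question. Also open, as far as these compounds go, is how a non-aromatic group such as cyclohexyl would read on this nitrogen, and whether the small gap seen here would hold for other rings.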